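The source may report more compounds than this note shows. Statements on the series, on what has been measured and on what is new or still open speak of the compounds shown alone.

Measured in an ADME assay on HepG2 cells (Homo sapiens), read by MTT assay, with a stated time of 72 h, in the presence of a further agent that is not named here; a higher number here means a weaker inhibitor, a lower number a stronger inhibitor:
- compound 1 `O=C(NCc1ccccc1)Oc1ccc(Cl)cc1C(=O)Nc1ccc(Cl)cc1`: 6400 nM
- compound 2 `O=C(Nc1ccccc1)Oc1ccc(Cl)cc1C(=O)Nc1ccc(Cl)cc1`: 900 nM
- compound 3 `O=C(Nc1ccccc1)Oc1ccccc1C(=O)Nc1ccccc1`: 26800 nM

Compound 1 holds the second highest of these three numbers. Compound 3, at 26800 nM, reads higher, and compound 2, at 900 nM, reads lower.

The next compound to be tested, compound 4 `O=C(NCc1ccccc1)Oc1ccc(Cl)cc1C(=O)Nc1ccc(Br)cc1`, keeps the core of compound 1 and changes one group: bromo in place of chloro on an aromatic carbon. Put simply, the 4-chlorophenyl of compound 1 becomes 4-bromophenyl.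

Among the measured compounds shown here, only one measured step links two compounds that differ in a single place: a 7.1-fold lower number from compound 1 to compound 2 (0.85 log units; beyond the scatter). That change is phenyl in place of benzyl on an amide-type nitrogen. It lies beyond the scatter, but it concerns another part of the molecule and offers only a loose guide to how far a single change can move the number. For the measured compounds named here, no measured pair shows bromo in place of chloro, so the direction stays open and no shift beyond the scatter is expected in this assay.

The expected step is a 1.2-fold lower number from compound 1 to compound 4 (0.07 log units; within the scatter), and this rests on compound 1 at 6400 nM as the starting point. For compound 4 the estimated value is 5500 nM, with an expected range from 2500 nM to 12000 nM.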

Compound 4, half-maximal inhibitory concentration: 1650 nM
The estimate for compound 4 lay 3.3-fold (0.52 log units) above the measured number, and the stated range ends above it.
By their numbers in this assay, from the lowest: compounds 2 and 4 (each within the scatter of the next); then compound 1; then compound 3.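

Exchanging chloro for bromo on the 4-chlorophenyl group gives a 3.9-fold lower number from compound 1 to compound 4 (0.59 log units; beyond the scatter) in this assay and shows that this position, para to a large group, responds to a single change beyond the scatter. Among the compounds shown here, the earlier compounds offered only one such step, a 7.1-fold lower number from compound 1 to compound 2 (0.85 log units; beyond the scatter), which comes from phenyl in place of benzyl on an amide-type nitrogen and says nothing about this position. The new step adds that replacing one halogen with another, with no ring, hydrogen-bond donor, hydrogen-bond acceptor or net charge entering or leaving, is enough to move the number beyond the scatter, though no available evidence explains why.

It remains open whether the step from chloro to bromo would appear in the same direction and size on the phenyl carbamate of compound 2, since the compounds shown test it only on the benzyl carbamate of compound 1. Nor do they show how fluoro, iodo, methyl, methoxy or a nitrile at this position would compare with chloro and bromo, so no trend across substituents can yet be drawn.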